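The source may report more compounds than this note shows. Statements on the series, on what has been measured and on what is new or still open speak of the compounds shown alone.

Compound 2 `Cc1c(O)nc(SCc2cccc(Cl)c2)nc1Cc1c(Cl)cccc1Cl` sits at a limit rather than at a number in a functional assay on MT4 cells (Homo sapiens) for cytotoxicity, read by MTT assay; on this read-out lower numbers stand for higher toxicity in this test and higher numbers for lower toxicity in this test: compound 2 gives > 59000 nM, which is a limit of the assay. Compound 1 `Cc1c(O)nc(SCc2ccc([N+](=O)[O-])cc2)nc1Cc1c(Cl)cccc1Cl` likewise reaches only a limit, since compound 1 gives > 58000 nM in this assay. For the measured compounds named here, the one measured step, a step that the two limits leave unreadable from compound 1 to compound 2, is therefore unreadable in size. Compound 3 `Cc1c(O)nc(SCc2ccc(Br)cc2)nc1Cc1c(Cl)cccc1Cl` differs from compound 2 by 4-bromophenyl in place of 3-chlorophenyl on a saturated chain carbon bound to a sulfur. No readable step bears on this change; the expectation for compound 3 is a step that the limit leaves unreadable from compound 2 to compound 3, none beyond the scatter, most likely ending again at a limit. Compound 3 is estimated at 60000 nM, within 30000 nM to 120000 nM.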

Compound 3, half-maximal cytotoxic concentration: 13000 nM
For compound 3 the middle estimate is 4.6-fold (0.66 log units) above the measured one; the measured number lies below the stated range.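

In this assay, for the compounds shown here, compound 3 is the first here to give a number rather than a limit, so this place, a saturated chain carbon bound to a sulfur, does register a change in the read-out. The change to 4-bromophenyl gives an at least 4.5-fold lower number from compound 2 to compound 3 (0.65 log units; beyond the scatter), and bromo in place of nitro on an aromatic carbon gives an at least 4.4-fold lower number from compound 1 to compound 3 (0.64 log units; beyond the scatter). Both sizes are minimums only, since compound 1 and compound 2 stand at limits of the assay.

As far as these compounds go, whether the bromine or its ring position carries the step stays open. A 4-chlorophenyl or 3-bromophenyl group at the same place would separate the two.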